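The source may report more compounds than this note shows. Statements on the series, on what has been measured and on what is new or still open speak of the compounds shown alone.

Series notes, solubility in phosphate buffer.

Compound 1 `CC(=O)c1cccc(Nc2cc(C)nc(-c3ccncc3)n2)c1` is the reference point of the set; in a physicochemical assay for solubility, in phosphate buffer (on this read-out lower numbers stand for lower solubility and higher numbers for higher solubility), compound 1 gives 29000 nM. Compound 2 `CC(=O)c1cc(Nc2cc(C)nc(-c3ccncc3)n2)ccc1F` carries one change against compound 1, fluoro in place of hydrogen on an aromatic carbon, and in this assay compound 2 gives 23000 nM; the step is a 1.3-fold lower number from compound 1 to compound 2 (0.10 log units; within the scatter). Compound 3 `CC(=O)c1ccc(Nc2cc(C)nc(-c3cccnc3)n2)cc1` has the same atoms as compound 1 joined differently; the difference between the two cores is not broken down here. In this assay compound 3 gives 94000 nM, the highest number of the three measured.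

Compound 4 `CC(=O)c1ccc(Nc2cc(C)nc(-c3cccnc3)n2)cc1F` is not yet measured. For the measured compounds named here, it differs from compound 3 by fluoro in place of hydrogen on an aromatic carbon, the same kind of change as the one from compound 1 to compound 2, though the place is not identical: in compound 2 the fluoro is para to a large group, in compound 4 it is meta to a large group. Going by the values given here, on the single prior instance, the step of a 1.3-fold lower number from compound 1 to compound 2 (0.10 log units; within the scatter) stayed within the scatter, so the step from compound 3 to compound 4 is expected to be similarly small, a 1.2-fold lower number from compound 3 to compound 4 (0.07 log units; within the scatter). For compound 4 the expected value in this assay is 80000 nM, with a likely range from 40000 nM to 160000 nM.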

Compound 4, solubility: 32000 nM
Compound 4: middle estimate off by 2.5-fold (0.40 log units), on the high side, and the stated range ends above it.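

In this assay, fluoro in place of hydrogen on an aromatic carbon gives a 2.9-fold lower number from compound 3 to compound 4 (0.47 log units; beyond the scatter), against a 1.3-fold lower number from compound 1 to compound 2 (0.10 log units; within the scatter), so on these two pairs the size of the step does not carry from one core to the other. This rests on a single pair for each core and does not show whether the core or the place of the fluoro accounts for the difference: in compound 4 the fluoro is ortho to an acetyl group and meta to a large group, and the place in compound 2 is not the same. Nothing available here bears on why the two steps differ.

Still open, going by these compounds, is whether the step from hydrogen to fluoro keeps its size at other places on the carbon-only ring of the core of compound 3. Also open, on these data alone, is how a chloro, a methoxy or an amine at the place of the fluoro in compound 4 would compare with that fluoro.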